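A few compounds are considered here, and "the series" means these few. Any claim that something is new, unique, unknown or untested is made for them only; others in the source may bear on it.

Measured compounds:
- Compound 1, `Nc1cc(N)c2nc(-c3ccccc3)c(NCc3ccc(F)cc3)nc2c1`: in a functional assay on NCI-H460 cells (Homo sapiens) for inhibition, read by sulforhodamine B assay, with a stated time of 48 h (a lower number here means a stronger inhibitor of growth, a higher number a weaker inhibitor of growth), compound 1 gives 25700 nM.
- Compound 2, `COc1ccc(Sc2nc3cc(N)cc(N)c3nc2-c2ccccc2)cc1`: in this assay compound 2 gives only a limit, < 100000 nM.

Compound 2 therefore stands on a limit rather than on a number, and its place among the values shown cannot be fixed. Within the data shown here, the only measured step, a step that the limit leaves unreadable from compound 1 to compound 2, puts (4-methoxyphenyl)sulfanyl in place of (4-fluorobenzyl)amino on an aromatic carbon, and its size cannot be read, (the limit of < 100000 nM in this assay, at which 1 of the 2 values shown sits).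

Compound 3, `Nc1cc(N)c2nc(-c3ccccc3)c(Sc3ccc(Cl)c(Cl)c3)nc2c1`, has not yet been measured in this assay. It differs from compound 2 by 3,4-dichlorophenyl in place of 4-methoxyphenyl on a sulfur. No measured step touches this position with a readable number on both sides, so the figures shown give no direction for this change, and the starting point itself is uncertain. The step from compound 2 to compound 3 is expected to be small, a step that the limit leaves unreadable from compound 2 to compound 3, with wide uncertainty. Compound 3 is estimated to give about 30000 nM in this assay, with a range from 5000 nM to 100000 nM.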

Compound 3, concentration for total growth inhibition: 33900 nM
Compound 3: middle estimate off by 1.1-fold (0.05 log units), on the low side; low and high end bracket the measured number.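

With compound 3, a sulfanyl group at this position has a readable number in this assay, so it can be set against the (4-fluorobenzyl)amino group of compound 1, and the swap gives a 1.3-fold higher number from compound 1 to compound 3 (0.12 log units; within the scatter). On this pair, then, (3,4-dichlorophenyl)sulfanyl and (4-fluorobenzyl)amino on the aromatic carbon cannot be told apart in this read-out, which means that this position accepts either group with no measurable difference in growth inhibition. The change on the sulfur from 4-methoxyphenyl to 3,4-dichlorophenyl, like the other step touching compound 2, cannot be read, because compound 2 holds only a limit and not a number: the limit of < 100000 nM in this assay, at which 1 of the 3 values shown sits.

From the compounds shown here alone, compound 1 and compound 3 differ at once in the atom linking the group to the core and in the ring that atom carries, so the contribution of each alone remains unknown. Also open, going by these compounds, is how this position would respond to a different kind of group on the sulfur, such as a carboxylic acid or a longer alkyl chain in place of the aromatic ring.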